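Cytotoxicity ceiling across the series: isopropyl to methyl

The source may report more compounds than this note shows. Statements on the series, on what has been measured and on what is new or still open speak of the compounds shown alone.

Compound 1 `CC(C)CC1(Cc2ccccc2)OS(=O)(=O)C=C1OCc1ccccc1` is the reference point. In an ADME assay on HEL cells (Homo sapiens) for cytotoxicity, with a stated time of 3 days (a lower number here means that less compound is tolerated, a higher number that more compound is tolerated), compound 1 gives >= 80000 nM, which is a limit of the assay and not a number. Compound 2 `CCC1(Cc2ccccc2)OS(=O)(=O)C=C1OCc1ccc(Cl)cc1` in this assay gives >= 50000 nM; this too is a limit. Compound 3 `CCC1(Cc2ccccc2)OS(=O)(=O)C=C1OCc1ccc(Cl)c(Cl)c1` in this assay gives >= 20000 nM, again a limit. The step that the two limits leave unreadable from compound 2 to compound 3 therefore cannot be read, as the limit of >= 50000 nM in this assay, at which 1 of the 3 values shown sits, and the limit of >= 20000 nM in this assay, at which 1 of the 3 values shown sits, show. Going by the values given here, every value so far sits at a limit, the limit of >= 80000 nM in this assay, at which 1 of the 3 values shown sits, included, so no measured step tells how a change at the saturated chain carbon would move the read-out.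

Compound 4 `CCC1(Cc2ccccc2)OS(=O)(=O)C=C1OCc1ccccc1` differs from compound 1 by methyl in place of isopropyl on a saturated chain carbon bound to a saturated ring carbon. Among the compounds with values here, no measured pair isolates this change; the one measured step, a step that the two limits leave unreadable from compound 2 to compound 3, concerns the aromatic ring and is itself unreadable. With three limits and nothing beyond them, compound 4 is expected also to reach a limit in this assay, estimated at 50000 nM with a range of 20000 nM to 100000 nM. Within the data shown here, the expected step of an at least 1.6-fold lower number from compound 1 to compound 4 (0.20 log units; that floor lies within the scatter) is taken as none beyond the scatter, the only reading the limits permit.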

Compound 4, minimum cytotoxic concentration: >= 50000 nM
Compound 4 gave a limit, no number; the forecaster's own chance of this, stated with the estimate: 85%; the middle value lies on the limit itself.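

Compound 4 also ends at a limit in this assay, so the steps linking it to compound 1, compound 2 and compound 3 cannot be read: the limit of >= 50000 nM in this assay, at which 2 of the 4 values shown sit.

The compounds shown leave open whether methyl in place of isopropyl, or chloro in place of hydrogen, moves the minimum cytotoxic concentration at all.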